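Aryl urea series: compound 4 adds a second tert-butyl group

The compounds below may be only part of what the source reports. "The series", "measured", "known", "first", "only" and "open" are said of these compounds alone.

Measured so far:
compound 1, `C[C@@H](NC(=O)Nc1ccccc1C(C)(C)C)c1ccccc1`, gives 100%
compound 2, `COc1ccccc1NC(=O)N[C@H](C)c1ccccc1`, gives 100%
compound 3, `C[C@@H](NC(=O)Nc1ccccc1F)c1ccccc1`, gives 97%

In an ADME assay on the whole organism with Oryza sativa as the target, tested at 0.1 uM (on this read-out lower numbers stand for a stronger effect and higher numbers for a weaker effect at the one concentration tested), compound 1 is level with compound 2 at the digits shown, and compound 3 lies within the scatter of both; no pair of the three values is separated beyond it.

Compound 4, `C[C@@H](NC(=O)Nc1cc(C(C)(C)C)ccc1C(C)(C)C)c1ccccc1`, differs from compound 1 by tert-butyl in place of hydrogen on an aromatic carbon. Among the compounds with values here, the steps that bear on it are those that swap the tert-butyl group of compound 1: no change at the digits printed from compound 1 to compound 2 (within the scatter) and a number 3 percentage points lower from compound 1 to compound 3 (within the scatter). Within the data shown here, no measured step adds a group to the ring, so the expectation rests on the flatness of the series. The step of a number 5 percentage points lower from compound 1 to compound 4 (within the scatter) is expected to stay within the scatter. Compound 4 is therefore estimated at 95%, with a range from 70% to 100%.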

Compound 4, a percentage reported as activity, at one concentration (the size of the read-out at that concentration, not a potency): 100%
Estimate against measurement, compound 4: 5 percentage points below; the range from low to high includes it.
By their numbers in this assay, from the lowest: compounds 3, 1, 2 and 4 (each within the scatter of the next).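

In this assay the added tert-butyl, para to a tert-butyl group, gives no change at the digits printed from compound 1 to compound 4 (within the scatter) and so extends the flat picture. Unlike the swaps among compounds 1, 2 and 3, this step fills a second place on the ring, and this position takes a group of 4 heavy atoms with no shift beyond the scatter. No evidence on hand bears on this result.

The compounds shown leave open whether an amine or a carboxylic acid at this position would move the read-out beyond the scatter. They also leave open whether any change on this ring can do so.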